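The source may hold more compounds than are shown below. What is called first, only, known or untested is meant among the compounds shown, and "the series" means these compounds.

Compounds measured in a functional assay on UACC-62 cells (Homo sapiens) for inhibition, read by sulforhodamine B assay, with a stated time of 48 h, tested at 10 uM; on this read-out lower numbers stand for less inhibition and higher numbers for more inhibition at the one concentration tested (going by the name of the read-out):
- compound 1 `c1ccc(-c2cn3ccnc3c(-c3ccc4ncn(C5CCCCC5)c4c3)n2)cc1`, giving 65.7%
- compound 2 `c1ccc2c(-c3cn4ccnc4c(-c4ccc5ncn(C6CCCCC6)c5c4)n3)cccc2c1`, giving 16.7%
- compound 3 `CC(=O)c1ccc(-c2cn3ccnc3c(-c3ccc4ncn(C5CCCCC5)c4c3)n2)cc1`, giving 18.5%

Compound 2 stands lowest of the three numbers in this assay. Compound 3 lies nearest to it, a number 1.8 percentage points higher from compound 2 to compound 3 (within the scatter), and compound 1 lies furthest from it, the gap being a number 49 percentage points lower from compound 1 to compound 2 (beyond the scatter). Compound 4 `Brc1ccc(-c2cn3ccnc3c(-c3ccc4ncn(C5CCCCC5)c4c3)n2)cc1` has not yet been measured; it differs from compound 2 by 4-bromophenyl in place of naphthalen-1-yl on an aromatic carbon.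

Going by the values given here, two measured steps bear on this change. Among the compounds with values here, the first is the one that gave compound 2 itself, a number 49 percentage points lower from compound 1 to compound 2 (beyond the scatter). The second replaces a hydrogen of the phenyl of compound 1 by acetyl, a number 47.2 percentage points lower from compound 1 to compound 3 (beyond the scatter); it shows that a 4-substituted phenyl can sit as low as the naphthalen-1-yl. Within the data shown here, compound 4 returns to a single six-membered ring but carries bromine where compound 3 carries acetyl, and no measured pair covers that group. Some recovery toward compound 1 is therefore possible, yet compound 3 warns that a 4-substituted phenyl may stay near compound 2. For compound 4 a moderate rise is expected, a number 18.3 percentage points higher from compound 2 to compound 4 (beyond the scatter), with wide uncertainty. The estimate for compound 4 in this assay is 35%, between 10% and 62%.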

Compound 4, a percentage reported as inhibition, at one concentration (the size of the read-out at that concentration, not a potency): 46.9%
The estimate for compound 4 lay 11.9 percentage points below the measured number, and the stated range covers the measured number.
By their numbers in this assay, from the lowest: compounds 2 and 3 (each within the scatter of the next); then compound 4; then compound 1.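

In this assay, the 4-bromophenyl in place of naphthalen-1-yl gives a number 30.2 percentage points higher from compound 2 to compound 4 (beyond the scatter), so on this aromatic carbon next to the ring nitrogen, a single six-membered aromatic ring bearing a substituent can recover much of the number lost with naphthalen-1-yl. Compound 3 had left open whether any substituent on the phenyl would hold the number down, but bromo in place of acetyl gives a number 28.4 percentage points higher from compound 3 to compound 4 (beyond the scatter), so the outcome depends on which group is carried there, and the low number does not follow from substitution alone. Bromo in place of hydrogen still gives a number 18.8 percentage points lower from compound 1 to compound 4 (beyond the scatter), placing the bromo compound at an intermediate level, with a real cost relative to the unsubstituted phenyl but a smaller one than acetyl brings.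

Nothing among the data shown accounts for these steps. Going by these compounds, whether a methoxy group, an amine, a carboxylic acid or a longer chain in place of the bromo would stay near compound 1 or fall toward compound 3 remains open, as does whether the order seen at this single concentration would hold across a full concentration range.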